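This account rests on a few compounds, and the source may have more. Where it says the series, first, only, none or still open, it means among the compounds named here.

Two compounds of the series have numbers in a functional assay on CHO-K1 cells for agonist activity at Glucose-dependent insulinotropic receptor (Homo sapiens), read by a luciferase reporter, with a stated time of 5 h (on this read-out higher numbers stand for an effect only at larger amounts of compound and lower numbers for an effect already at smaller amounts), so far. Compound 1 `CC(C)OC(=O)N1CCC(Oc2ncnc3c2CCN3c2ccc(S(C)(=O)=O)cc2)CC1` gives 126 nM in this assay. For the measured compounds named here, compound 2 `CC(C)OC(=O)N1CCC(Oc2ncnc3c2CCN3c2ccc(C#N)c(F)c2)CC1` gives 398 nM in this assay, and this is the higher of the two numbers; the only step on record is a 3.2-fold higher number from compound 1 to compound 2 (0.50 log units; beyond the scatter).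

Compound 3 `CC(C)OC(=O)N1CCC(Oc2ncnc3c2CCN3c2ccc(S(C)(=O)=O)c(F)c2)CC1` has not been measured in this assay. It differs from compound 2 at one place: methylsulfonyl in place of cyano on an aromatic carbon. The change sits on an aromatic carbon of a six-membered aromatic ring of carbon only, ortho to a fluoro group and para to a large group, so that 4-cyano-3-fluorophenyl becomes 3-fluoro-4-(methylsulfonyl)phenyl.

Going by the values given here, no measured step reports this exact swap with the fluoro group kept. The nearest comparison is the step from compound 1 to compound 2, which moved methylsulfonyl out and cyano plus fluoro in; for compound 3 the methylsulfonyl returns while the fluoro group stays. The step from compound 2 to compound 3 in this assay is therefore expected to run in the opposite direction, as a 2.5-fold lower number from compound 2 to compound 3 (0.40 log units; beyond the scatter), with the fluoro group leaving the outcome uncertain. Compound 3 is estimated at 160 nM in this assay, with a range from 60 nM to 450 nM.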

Compound 3, half-maximal effective concentration: 158 nM
The estimate for compound 3 lay 1.0-fold (0.01 log units) above the measured number; the measured number falls inside the stated range.
By their numbers in this assay, from the lowest: compounds 1 and 3 (each within the scatter of the next); then compound 2.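

Methylsulfonyl in place of cyano, with the fluoro group kept, gives a 2.5-fold lower number from compound 2 to compound 3 (0.40 log units; beyond the scatter) in this assay, which isolates the exchange at this aromatic carbon, para to a large group; the earlier step changed this group and added the fluoro group at once, so it could not assign the shift to either change. Fluoro in place of hydrogen on the methylsulfonyl-bearing ring gives a 1.3-fold higher number from compound 1 to compound 3 (0.10 log units; within the scatter), so within these three compounds the fluoro group alongside methylsulfonyl leaves no difference that can be told from the scatter, and the gap separating compound 2 from the other two goes with cyano against methylsulfonyl. Nothing on record explains why these two groups differ at this carbon.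

On these data alone, whether the fluoro group counts for as little alongside cyano as it does alongside methylsulfonyl stays open. Also open, as far as these compounds go, is how other groups at this aromatic carbon, such as a sulfonamide, a carboxylic acid or an amine, would compare with methylsulfonyl on this read-out.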